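The compounds below may be only part of what the source reports. "The series", "measured", "known", "first", "only" and "open" are said of these compounds alone.

Working notes on the series in an ADME assay on MT4 cells (Homo sapiens) for cytotoxicity, read by MTT assay, with a stated time of 4 days; on this read-out higher numbers stand for lower toxicity in this test and lower numbers for higher toxicity in this test. Of the compounds shown here, two have numbers so far. Among the compounds with values here, compound 1 `C/C(=N\NC(=O)COc1cccc2ccccc12)c1ccc(C#N)cc1Br` gives 12.1 ug/mL in this assay, and compound 2 `O=C(COc1cccc2ccccc12)N/N=C/c1ccccc1[N+](=O)[O-]` gives 12.2 ug/mL in this assay; the two numbers sit within the scatter of each other, so compound 1 stands level with the only other measured compound and neither can be placed ahead of the other.

The next compound, compound 3 `C/C(=N\NC(=O)COc1cccc2ccccc12)c1cccc([N+](=O)[O-])c1`, has not yet been run in this assay. Its structure differs from that of compound 1 in one place: 3-nitrophenyl in place of 2-bromo-4-cyanophenyl on a carbon with a double bond to nitrogen. Within the data shown here, no pair of measured compounds differing in one place is available, so the size of this kind of change in this assay is unknown from the data. Among the measured compounds shown here, with only two values, both alike, the expectation for compound 3 in this assay is no movement beyond the scatter, that is a 1.0-fold lower number from compound 1 to compound 3 (0.00 log units; within the scatter). Compound 3 is therefore estimated at 12 ug/mL in this assay, with a range of 5 ug/mL to 30 ug/mL.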

Compound 3, half-maximal cytotoxic concentration: 12.1 ug/mL
For compound 3 the middle estimate is 1.0-fold (0.00 log units) below the measured one; low and high end bracket the measured number.
By their numbers in this assay, from the lowest: compounds 1, 3 and 2 (each within the scatter of the next).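

Replacing 2-bromo-4-cyanophenyl with 3-nitrophenyl on a carbon with a double bond to nitrogen gives no change at the digits printed from compound 1 to compound 3 (within the scatter) in this assay. Within the data shown here, this is the first one-place step, and it shows that this position can take a different substituted phenyl of the same heavy-atom count, with bromine and nitrile leaving and nitro entering, without a shift beyond the scatter. No measurement at hand offers an explanation for this flat result.

From the compounds shown here alone, whether an amine or a carboxylic acid on the phenyl ring, or a longer chain in place of that ring, would move the number beyond the scatter remains open. The reading for this position also rests on a single pair, so it cannot yet be extended to other groups.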